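Methyl in Place of Chloro on the Sulfonamide Ring

This account rests on a few compounds, and the source may have more. Where it says the series, first, only, none or still open, it means among the compounds named here.

Compound 1, `C=Cc1ccc(S(=O)(=O)Nc2ccc3oc(-c4ccccc4)nc3c2)cc1`: > 100000 nM
Compound 2, `O=S(=O)(Nc1ccc(-c2nc3ccccc3o2)cc1)c1cccc(Cl)c1`: 54000 nM
Compound 3, `O=S(=O)(Nc1ccc2oc(-c3ccccc3)nc2c1)c1ccc(Cl)cc1`: > 100000 nM

In an assay on cells for inhibition of HSP60/HSP10 (Homo sapiens), with a stated time of 60 min (on this read-out lower numbers stand for stronger inhibition and higher numbers for weaker inhibition), compound 1 reaches only a limit of the assay, > 100000 nM. Compound 3 likewise reaches only a limit, > 100000 nM. Among the compounds with values here, compound 2 is the one compound with a measured number, 54000 nM. The two further values sit at the limit, where two of the three values stand (the limit of > 100000 nM in this assay, at which 2 of the 3 values shown sit). Within the data shown here, the single step between measured compounds, a step that the two limits leave unreadable from compound 1 to compound 3, cannot be read in size, since both ends are limits.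

Compound 4, `Cc1cccc(S(=O)(=O)Nc2ccc(-c3nc4ccccc4o3)cc2)c1`, differs from compound 2 in one place: methyl in place of chloro on an aromatic carbon. Among the measured compounds shown here, no measured step compares chloro with methyl, and the one step that exists is unreadable, so nothing in the data points to a change in either direction. The step from compound 2 is therefore expected to stay within the scatter, no change at the digits printed from compound 2 to compound 4 (within the scatter). Compound 4 is estimated at 54000 nM, with a range from 20000 nM to 150000 nM.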

Compound 4, half-maximal inhibitory concentration: > 100000 nM
Compound 4: only a limit was reported; the forecaster's own chance of this, stated with the estimate: 30%; middle value at least 1.8-fold (0.26 log units) away from the limit.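

In this assay, within the data shown here, the change from 3-chlorophenyl to 3-methylphenyl gives the first step in this set with a readable lower end, which the earlier compounds did not offer: an at least 1.8-fold higher number from compound 2 to compound 4 (0.26 log units; that floor lies within the scatter). Methyl at this position therefore does not bring a lower number than chloro, but the true size of the step stays unknown, since compound 4 gives only a limit and the floor of the step lies within the scatter. Compound 2 remains the only compound with a measured number, and the limit now holds most of the set: the limit of > 100000 nM in this assay, at which 3 of the 4 values shown sit.

On these data alone, how far compound 4 really lies from compound 2 remains open. So does whether another group at this position, such as an amine or a carboxylic acid, would give a number lower than that of compound 2.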